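The source may report more compounds than this note shows. Statements on the series, on what has been measured and on what is new or still open speak of the compounds shown alone.

Measured in a functional assay on KB cells (Homo sapiens) for cytotoxicity, read by MTT assay, with a stated time of 48 h; on this read-out higher numbers stand for weaker inhibition and lower numbers for stronger inhibition:
compound 1 `CCn1cc(-c2nc3ccccc3[nH]2)c(=O)c2cc(F)c(N3CCNCC3)nc21`: 2000 nM
compound 2 `CCn1cc(-c2nc3ccccc3s2)c(=O)c2cc(F)c(N3CCNCC3)nc21`: 2400 nM
compound 3 `CCn1cc(-c2nc3ccc([N+](=O)[O-])cc3s2)c(=O)c2cc(F)c(N3CCNCC3)nc21`: 179000 nM

Compound 2 lies level with compound 1, and both lie far under compound 3. The step of interest leads to compound 4 `CCn1cc(-c2nc3ccc(N)cc3[nH]2)c(=O)c2cc(F)c(N3CCNCC3)nc21`, (a group of 10 heavy atoms (7 carbon, 3 nitrogen; one five-membered aromatic ring with 2 hetero atoms, one six-membered aromatic ring of carbon only) in place of a group of 9 heavy atoms (7 carbon, 1 nitrogen, 1 sulfur; one five-membered aromatic ring with 2 hetero atoms, one six-membered aromatic ring of carbon only), on an aromatic carbon). Among the measured compounds shown here, two measured steps bear on it. Exchanging the two groups on the shared core gave a 1.2-fold higher number from compound 1 to compound 2 (0.08 log units; within the scatter), whereas nitro in place of hydrogen gave a 75-fold higher number from compound 2 to compound 3 (1.87 log units; beyond the scatter). Only compound 3, at 179000 nM, carries nitro, and compound 4 does not. For the measured compounds named here, no measured compound carries the extra substituent of compound 4, so the uncertainty stays wide. In this assay, a small upward step or none beyond the scatter is expected: a 1.3-fold higher number from compound 2 to compound 4 (0.10 log units; within the scatter). The estimate for compound 4 is 3000 nM, within 700 nM to 20000 nM.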

Compound 4, half-maximal inhibitory concentration: 30100 nM
The estimate for compound 4 lay 10-fold (1.00 log units) below the measured number, outside the stated range (above it).
By their numbers in this assay, from the lowest: compounds 1 and 2 (each within the scatter of the next); then compound 4; then compound 3.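

In this assay, amino in place of hydrogen on the 1H-benzimidazol-2-yl group gave a 15-fold higher number from compound 1 to compound 4 (1.18 log units; beyond the scatter), so nitro in a 75-fold higher number from compound 2 to compound 3 (1.87 log units; beyond the scatter) is no longer the only substituent on the carbon-only six-membered ring linked to a large rise. The step of a 13-fold higher number from compound 2 to compound 4 (1.10 log units; beyond the scatter) is also large, whereas the unsubstituted exchange gave only a 1.2-fold higher number from compound 1 to compound 2 (0.08 log units; within the scatter). A substituted group of this kind can therefore weaken the cytotoxic read-out even where the bare groups sit within the scatter.

From the compounds shown here alone, it remains open whether a small group such as methyl or chloro on that ring would raise the number as well. The data offered here give no explanation for the rise.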